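The source may hold more compounds than are shown below. What is called first, only, known or untested is meant among the compounds shown, and "the series" means these compounds.

Measured compounds in a functional assay on a cell-free system (plasma, Homo sapiens), with a stated time of 3 min; a lower number here means a stronger inhibitor, a higher number a weaker inhibitor:
- compound 1, `CC(C)(C)[C@@H](O)C(=O)N1CSC[C@H]1C(=O)NCc1cc(Cl)ccc1-n1cnnn1`, 1200 nM
- compound 2, `O=C(NCc1cc(Cl)ccc1-n1cnnn1)[C@@H]1[C@H]2C[C@H]2CN1C(=O)[C@H](O)CC1CC1`, 1400 nM
- compound 3, `CCCC[C@@H](O)C(=O)N1N=CC[C@H]1C(=O)NCc1cc(Cl)ccc1-n1cnnn1`, 610 nM

Compound 2 carries the highest number of the three in this assay. Its nearest neighbour is compound 1, whose value sits within the scatter of repeated measurements, so the two cannot be ordered. Compound 3 stands furthest from compound 2, with a gap that lies beyond the scatter, so compound 3 inhibits more strongly than compound 2 on these numbers. Compounds 1 and 3 differ from compound 2 in more than one place, so no single step can be read from them.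

Compound 4, `O=C(NCc1cc(Cl)ccc1-n1cnnn1)[C@@H]1[C@H]2C[C@H]2CN1C(=O)[C@H](O)c1ccccc1`, has not yet been measured. It differs from compound 2 in one place:

phenyl in place of cyclopropylmethyl on a saturated chain carbon bound to a carbonyl carbon and an oxygen on a saturated carbon

No measured pair in this set isolates this change, so its direction rests on general experience with side chains at this position rather than on a shown step. A modest move toward a lower number is expected, of a size near or a little beyond the scatter, with a sizable chance of no change at all.

For compound 4 the estimate in this assay is 750 nM, in the range 250 nM to 2500 nM, which means an expected step of a 1.9-fold lower number from compound 2 to compound 4 (0.27 log units; within the scatter).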

Compound 4, half-maximal inhibitory concentration: 960 nM
Beside the measured number, compound 4's estimate is 1.3-fold (0.11 log units) below it; low and high end bracket the measured number.
By their numbers in this assay, from the lowest: compounds 3, 4, 1 and 2 (each within the scatter of the next, the first and the last beyond it).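

In this assay, phenyl in place of cyclopropylmethyl on a saturated chain carbon bound to a carbonyl carbon and an oxygen gives a 1.5-fold lower number from compound 2 to compound 4 (0.16 log units; within the scatter), the only step among the compounds shown that isolates a change in one place. At this position on the core of compound 2, the two groups therefore cannot be told apart: a six-membered aromatic ring of carbon only and a three-membered non-aromatic ring of carbon only, carried on a chain carbon, give values within the scatter of each other. No supporting data bear on this result.

A single pair on a single core leaves open whether the same exchange would read alike on the cores of compound 1 and compound 3. It also leaves open whether a group of a different kind at this place, such as an amine, a carboxylic acid or a longer chain, would give a step beyond the scatter from compound 2 in this assay.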